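The compounds below may be only part of what the source reports. "The series", "measured", "known", "first", "only" and "open" are said of these compounds alone.

Three compounds have been measured in an ADME assay on HEK293 cells (Homo sapiens) for inhibition, read by MTT assay, with a stated time of 2 days; a lower number here means a stronger inhibitor, a higher number a weaker inhibitor:

Compound 1, `COc1ccc(/C=C/c2cccc(O)c2)cc1`, gives 24 ug/mL.
Compound 2, `COc1cccc(/C=C/c2ccc(O)cc2)c1`, gives 24 ug/mL.
Compound 3, `COc1ccc(/C=C/c2cccc(N)c2)cc1`, gives 11 ug/mL.

Compounds 1 and 2 are built from the same atoms joined differently; the difference between the two cores is not broken down here. In this assay compound 1 and compound 2 sit at the same number at the digits given, so nothing separates them there. Compound 3 differs from compound 1 in one place: amino in place of hydroxy on an aromatic carbon. That single change produced a 2.2-fold lower number from compound 1 to compound 3 (0.34 log units; beyond the scatter), a modest step, but one that reaches beyond the usual scatter of this kind of measurement.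

Compound 4, `COc1cccc(/C=C/c2ccc(N)cc2)c1`, has not yet been measured. It differs from compound 2 in one place: amino in place of hydroxy on an aromatic carbon. Within the data shown here, this is the same kind of change as the one made between compound 1 and compound 3, but the surroundings are not identical: in compound 3 the new group sits meta to a large group, while in compound 4 it sits para to a large group. Among the measured compounds shown here, with only one earlier example of this change, and that at a different placement, the expectation rests on a single step. Because the earlier change gave a 2.2-fold lower number from compound 1 to compound 3 (0.34 log units; beyond the scatter), a step of about the same size is expected for compound 4, namely a 2.2-fold lower number from compound 2 to compound 4 (0.34 log units; beyond the scatter). On that basis compound 4 is expected to give about 11 ug/mL in this assay, with a likely range from 6 ug/mL to 22 ug/mL.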

Compound 4, half-maximal inhibitory concentration: 18 ug/mL
Beside the measured number, compound 4's estimate is 1.6-fold (0.21 log units) below it, and the stated range covers the measured number.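

In this assay, among these compounds, the swap of hydroxy for amino on an aromatic carbon gave a 1.3-fold lower number from compound 2 to compound 4 (0.12 log units; within the scatter), so on this second core the change produces no step that stands clear of repeat measurements. Set beside the earlier step, the new one cannot be told apart from it, even though only the earlier step reaches beyond the scatter: the same change on two cores in this assay, a 2.2-fold lower number (0.34 log units; beyond the scatter) from compound 1 to compound 3 and a 1.3-fold lower number (0.12 log units; within the scatter) from compound 2 to compound 4, 1.6-fold (0.21 log units) apart, within the scatter of two such steps. This means the two results are compatible with the change carrying over from one core to the other with a similar size, but two steps are too few to establish this, and they do not show whether the true size is the same on both cores or whether the amino group's placement, para to a large group in compound 4, affects the result.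

The compounds shown leave open whether other groups in this place, such as a methylamino group, a fluorine atom or an acetamide, would shift the number in this assay in the same direction as amino. They also leave open whether the swap of hydroxy for amino would give a step of similar size on any core beyond these two.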